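This account rests on a few compounds, and the source may have more. Where it says the series, first, only, none or still open, it means among the compounds named here.

Compound 1 `CCCCCCCn1c(N2CCN(C)CC2)nc2ccccc21` is one of three compounds tested in a functional assay on ileum for inhibition of histamine H1 receptor (Cavia porcellus) (on this read-out higher numbers stand for weaker inhibition and lower numbers for stronger inhibition), and compound 1 gives 150 nM, the highest of the three numbers. Compound 2 `CCCCN1CCN(c2nc3ccccc3n2CCOCC)CC1` gives 15 nM in this assay, and compound 3 `CCCOCCn1c(N2CCCN(C)CC2)nc2ccccc21` gives 16 nM. Both of those numbers lie well beyond the scatter from the number of compound 1, yet each of these two compounds differs from compound 1 in more than one place, so no single structural step can be read from them.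

Compound 4 `COCCn1c(N2CCN(C)CC2)nc2ccccc21` is the next compound to be measured. It differs from compound 1 in one place: methoxy in place of pentyl on a saturated chain carbon, two bonds along the chain from an aromatic nitrogen. Within the data shown here, since no step between measured compounds is available, the expectation rests on the fact that compounds 2 and 3, which also carry shorter chains ending in an oxygen-bearing group, both gave lower numbers than compound 1. The step from compound 1 to compound 4 is expected to be a 4.3-fold lower number from compound 1 to compound 4 (0.63 log units; beyond the scatter), toward a lower number. Compound 4 is estimated at 35 nM, within a range from 10 nM to 120 nM.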

Compound 4, half-maximal inhibitory concentration: 13 nM
Compound 4: the middle estimate sits 2.7-fold (0.43 log units) above what was measured, and the stated range covers the measured number.
By their numbers in this assay, from the lowest: compounds 4, 2 and 3 (each within the scatter of the next); then compound 1.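

Methoxy in place of pentyl on a saturated chain carbon, two bonds along the chain from an aromatic nitrogen, gives a 12-fold lower number from compound 1 to compound 4 (1.06 log units; beyond the scatter) in this assay, a large step. Unlike the earlier comparisons, this one can be tied to a single change, so this place on the chain clearly matters in this assay: read one bond further out, heptyl gives way to 2-methoxyethyl while the rest of the molecule stays the same. No measurement shown here explains why the number falls.

The change shortens the chain and brings in an oxygen at once, so this step cannot separate the two. A plain carbon chain of the same length as 2-methoxyethyl, or a hydroxyl or an amine in place of methoxy, would be needed to tell them apart.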